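A few compounds are considered here, and "the series" means these few. Any claim that something is new, unique, unknown or untested is made for them only; others in the source may bear on it.

Measured compounds:
- compound 1, `c1ccc(-c2nc(-c3c[nH]c4ccccc34)co2)cc1`, in a functional assay on PC-3 cells (Homo sapiens) for cytotoxicity, read by MTT assay, with a stated time of 48 h (a lower number here means a stronger inhibitor, a higher number a weaker inhibitor), compound 1 gives 170000 nM
- compound 2, `Fc1ccc(-c2nc(-c3c[nH]c4ccccc34)co2)cc1`, in this assay compound 2 gives 42800 nM
- compound 3, `C(=C/c1nc(-c2c[nH]c3ccccc23)co1)\c1ccccc1`, in this assay compound 3 gives 221000 nM

Compound 2 holds the lowest number of the three in this assay; compound 1 sits a step above it, a 4.0-fold lower number from compound 1 to compound 2 (0.60 log units; beyond the scatter), and compound 3 lies further still, as its value next to that of compound 2 shows.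

Compound 4, `C=Cc1nc(-c2c[nH]c3ccccc23)co1`, is not yet measured. It differs from compound 2 in one place: vinyl in place of 4-fluorophenyl on an aromatic carbon.

Within the data shown here, only one measured step touches this position, the step from compound 1 to compound 2, where fluoro in place of hydrogen on the ring gave a 4.0-fold lower number from compound 1 to compound 2 (0.60 log units; beyond the scatter). Compound 4 loses the ring that carries that fluorine altogether, so the gain seen in compound 2 is not expected to carry over. Compound 3, which also bears an open-chain group at this position, shows a higher number than compound 1. For compound 4 a weaker result than compound 2 is therefore expected, and the expected step is a 4.7-fold higher number from compound 2 to compound 4 (0.67 log units; beyond the scatter). Compound 4 is estimated at 200000 nM, with a range from 60000 nM to 600000 nM.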

Compound 4, half-maximal inhibitory concentration: 426000 nM
Compound 4: the middle estimate sits 2.1-fold (0.33 log units) below what was measured; the measured number falls inside the stated range.
By their numbers in this assay, from the lowest: compound 2; then compounds 1, 3 and 4 (each within the scatter of the next, the first and the last beyond it).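

In this assay, the change to vinyl moves the number the opposite way from the fluoro step, with a 10-fold higher number from compound 2 to compound 4 (1.00 log units; beyond the scatter) on replacing 4-fluorophenyl. The loss is not limited to the compound that carries the fluorine. The plain phenyl of compound 1 also holds a lower number, with a 2.5-fold higher number from compound 1 to compound 4 (0.40 log units; beyond the scatter) on the same exchange, so at this carbon of the five-membered ring the aromatic ring itself counts, not only what it carries. No measurement at hand explains why the vinyl group does worse than either ring.

The compounds shown leave open whether a saturated ethyl chain or a longer chain would behave as vinyl does. They also leave open how an amine or a carboxylic acid on the phenyl ring, or a chlorine in place of the fluorine, would move the number.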